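A few compounds are considered here, and "the series" means these few. Any claim that something is new, unique, unknown or untested is made for them only; others in the source may bear on it.

Of the compounds shown here, three built on one shared core have been tested in a functional assay on U-87MG ATCC cells (Homo sapiens) for antiproliferative activity, read by MTT assay, with a stated time of 48 h; a lower number here means a stronger inhibitor, a higher number a weaker inhibitor. Compound 1 `O=C(/C=C\Nc1ccc(F)cc1)c1cn(-c2ccccc2)nc1-c1ccccc1` gives 10200 nM, compound 2 `O=C(/C=C\Nc1ccc(O)cc1)c1cn(-c2ccccc2)nc1-c1ccc(F)cc1` gives 4700 nM, and compound 3 `COc1cc(-c2nn(-c3ccccc3)cc2C(=O)/C=C\Nc2ccc(F)cc2)cc(OC)c1OC` gives 4780 nM. Compound 3 and compound 2 sit within the usual scatter of each other, while compound 1 gives a number that lies beyond the scatter above that of compound 3. Compound 4 `COc1cc(-c2nn(-c3ccccc3)cc2C(=O)/C=C\Nc2ccc(Cl)cc2)cc(OC)c1OC` differs from compound 3 by chloro in place of fluoro on an aromatic carbon, para to a large group. Among the compounds with values here, no measured pair shows this particular change, so the expectation rests on its small size. The step in this assay that this change is expected to bring is small, in no firm direction, and likely within the scatter, namely a 1.2-fold lower number from compound 3 to compound 4 (0.08 log units; within the scatter). Compound 4 is therefore estimated at 4000 nM, with a range from 1500 nM to 11000 nM.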

Compound 4, half-maximal inhibitory concentration: 3210 nM
The estimate for compound 4 lay 1.2-fold (0.10 log units) above the measured number; measured number inside the range.
By their numbers in this assay, from the lowest: compounds 4, 2 and 3 (each within the scatter of the next); then compound 1.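

In this assay, chloro in place of fluoro on the (4-fluorophenyl)amino group gives a 1.5-fold lower number from compound 3 to compound 4 (0.17 log units; within the scatter) and so stays within the usual scatter. Within the data shown here, this is the first pair here that differs in one place only, and it shows that this position accepts either halogen with no readable change in the number. No supporting measurement bears on why the two compounds read alike.

From the compounds shown here alone, whether a larger halogen such as bromo, or an amine, a nitrile or a carboxylic acid, at this same place would shift the number beyond the scatter remains open.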